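Swapping Nitro for Dimethylamino on a Shared Core

This account rests on a few compounds, and the source may have more. Where it says the series, first, only, none or still open, it means among the compounds named here.

Three compounds share one core and differ only in the group carried on the aromatic ring. Compound 1 `Cc1ccc(/C=C/C=C2\CCC=CC2=O)cc1` gives 7200 nM in a functional assay on HCT-116 cells (Homo sapiens) for cytotoxicity, read by MTT assay, with a stated time of 72 h; a higher number here means a weaker inhibitor, a lower number a stronger inhibitor. Compound 2 `O=C1C=CCC/C1=C\C=C\c1ccc(F)cc1` gives 2200 nM in this assay, and compound 3 `O=C1C=CCC/C1=C\C=C\c1ccc([N+](=O)[O-])cc1` gives 5000 nM. Among these three numbers compound 3 stands second highest: its nearest neighbour is compound 1, and the difference a 1.4-fold lower number from compound 1 to compound 3 (0.16 log units; within the scatter) lies within the scatter, while the step of a 2.3-fold higher number from compound 2 to compound 3 (0.36 log units; beyond the scatter) is modest but beyond it. The measured step of a 3.3-fold lower number from compound 1 to compound 2 (0.51 log units; beyond the scatter) is the largest of the set.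

Compound 4 `CN(C)c1ccc(/C=C/C=C2\CCC=CC2=O)cc1` differs from compound 3 in one place: dimethylamino in place of nitro on an aromatic carbon. For the measured compounds named here, the steps that bear on this change are those ending at compound 3, a 1.4-fold lower number from compound 1 to compound 3 (0.16 log units; within the scatter) and a 2.3-fold higher number from compound 2 to compound 3 (0.36 log units; beyond the scatter), both small, and neither of them involves a dimethylamino group, so no measured step tells directly how this exchange acts. Three different groups at the same aromatic carbon span only a modest range of numbers, which suggests a step in this assay that is expected to stay within the scatter, with no direction favoured. Compound 4 is therefore estimated at 5000 nM, between 1500 nM and 16000 nM. The expected step of no change at the digits printed from compound 3 to compound 4 (within the scatter) is small.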

Compound 4, half-maximal inhibitory concentration: 1200 nM
Compound 4: middle estimate off by 4.2-fold (0.62 log units), on the high side, outside the stated range (below it).
By their numbers in this assay, from the lowest: compounds 4 and 2 (each within the scatter of the next); then compounds 3 and 1 (each within the scatter of the next).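

At this aromatic carbon, para to a large group, the exchange of nitro for dimethylamino gives a 4.2-fold lower number from compound 3 to compound 4 (0.62 log units; beyond the scatter) in this assay, a step beyond the scatter that shows this position to be more responsive than compounds 1, 2 and 3 alone had indicated. Set against methyl, the same group gives a 6.0-fold lower number from compound 1 to compound 4 (0.78 log units; beyond the scatter) and this is the widest step in the set, whereas a 1.8-fold lower number from compound 2 to compound 4 (0.26 log units; within the scatter) places dimethylamino and fluoro within the scatter of each other, so two quite different groups share the low end of the range, with nitro and methyl together at the high end. No accompanying measurement is available to account for these differences.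

Still open, on these data alone, is whether another nitrogen group, such as a plain amino group or a morpholine ring, would fall with compounds 2 and 4 or with compounds 1 and 3, and where a methoxy group or a carboxylic acid at this carbon would land. Also open, as far as these compounds go, is whether dimethylamino would keep this standing if it were carried on a different carbon of the aromatic ring.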